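Swapping the piperazine tail for a sulfonamido-piperidine

The source may report more compounds than this note shows. Statements on the series, on what has been measured and on what is new or still open speak of the compounds shown alone.

Measured so far:
Compound 1, `Cc1cc(/C=C/C#N)cc(C)c1Oc1nc(Nc2ccc(CN3CCN(S(C)(=O)=O)CC3)cc2)nc2ccsc12`, 20700 nM in an ADME assay on MT4 cells (Homo sapiens) for cytotoxicity, read by MTT assay, with a stated time of 5 days; a lower number here means that less compound is tolerated, a higher number that more compound is tolerated.
Compound 2, `Cc1cc(/C=C/C#N)cc(C)c1Oc1nc(Nc2ccc(N3CCN(S(C)(=O)=O)CC3)cc2)nc2ccsc12`, 11500 nM in this assay.
Compound 3, `Cc1cc(/C=C/C#N)cc(C)c1Oc1nc(Nc2ccc(CN3CCN(S(N)(=O)=O)CC3)cc2)nc2ccsc12`, 145000 nM in this assay.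

Compound 3 has the highest number of the three, and the steps of a 7.0-fold higher number from compound 1 to compound 3 (0.85 log units; beyond the scatter) and a 13-fold higher number from compound 2 to compound 3 (1.10 log units; beyond the scatter) both lie beyond the scatter, so it is the most tolerated compound here. The step of a 1.8-fold lower number from compound 1 to compound 2 (0.26 log units; within the scatter) is small.

Compound 4 is `Cc1cc(/C=C/C#N)cc(C)c1Oc1nc(Nc2ccc(N3CCCC(NS(C)(=O)=O)C3)cc2)nc2ccsc12`. It differs from compound 3 by 3-(methanesulfonamido)piperidin-1-yl in place of (4-sulfamoylpiperazin-1-yl)methyl on an aromatic carbon. Going by the values given here, no measured step covers this exact change. The closest comparison is a 13-fold higher number from compound 2 to compound 3 (1.10 log units; beyond the scatter), where a group joined directly to the ring gave way to one joined through a methylene and carrying a sulfamoyl, and the number rose. Compound 4 moves back to direct attachment, as in compound 2, while keeping a sulfonamide. A move back toward the numbers of compound 1 and compound 2 is therefore expected, though an incomplete one: the step of a 4.8-fold lower number from compound 3 to compound 4 (0.68 log units; beyond the scatter) is the estimate. Compound 4 is expected at about 30000 nM, between 8000 nM and 120000 nM.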

Compound 4, half-maximal cytotoxic concentration: > 217000 nM
Compound 4 was reported as a limit; the forecaster's own chance of this, stated with the estimate: 10%; at least 7.2-fold (0.85 log units) between middle value and limit.
By their numbers in this assay, from the lowest: compounds 2 and 1 (each within the scatter of the next); then compound 3. At a limit, above all of these: compound 4.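

In this assay, compound 4 gives a limit rather than a number: the limit of > 217000 nM in this assay, at which 1 of the 4 values shown sits. Direct attachment to the aromatic ring therefore does not by itself bring a low number, since 3-(methanesulfonamido)piperidin-1-yl is attached there directly and the listed steps are an at least 18-fold higher number from compound 2 to compound 4 (1.27 log units; beyond the scatter) and an at least 10-fold higher number from compound 1 to compound 4 (1.02 log units; beyond the scatter). The comparison with compound 3 settles less, as the step is an at least 1.4-fold higher number from compound 3 to compound 4 (0.17 log units; that floor lies within the scatter), and that floor does not place the two compounds in any order.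

The compounds shown do not separate the effect of exchanging the piperazine ring for a piperidine from that of changing how the sulfonyl group is joined. From the compounds shown here alone, how a plain amine or a carboxylic acid would read in place of the methanesulfonamido group on the same piperidine also remains open.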